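The source may report more compounds than this note shows. Statements on the series, on what has been measured and on what is new or still open speak of the compounds shown alone.

Measured so far in an ADME assay on NCM460 cells (Homo sapiens) for cytotoxicity, read by MTT assay, with a stated time of 72 h; a higher number here means a weaker inhibitor, a lower number a stronger inhibitor:

- compound 1 : `COc1cc(NC(=O)c2cccc(/C=C3\CC(=O)N(c4ccccc4)C3=O)c2)cc(OC)c1OC`, > 100000 nM
- compound 2 : `CCOc1ccc(NC(=O)c2cccc(/C=C3\CC(=O)N(Cc4ccccc4)C3=O)c2)cc1`, > 100000 nM
- compound 3 : `COc1ccc(OC)c(NC(=O)c2cccc(/C=C3\CC(=O)N(c4ccccc4)C3=O)c2)c1`, > 100000 nM

Compound 2 gives only a limit of this assay, > 100000 nM, and not a number. The same holds for compound 1, whose reading is a limit as well. Compound 3 likewise sits at a limit. All values shown stand at the same limit (the limit of > 100000 nM in this assay, at which 3 of the 3 values shown sit), so compound 2 cannot be placed above or below either of the others; the three are indistinguishable on what has been measured.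

Compound 4 (`O=C(Nc1ccc(Cl)cc1)c1cccc(/C=C2\CC(=O)N(Cc3ccccc3)C2=O)c1`) is the next member and differs from compound 2 in one place: chloro in place of ethoxy on an aromatic carbon. For the measured compounds named here, no step between measured compounds is available to calibrate this change. Given that every measured member sits at the limit, no step beyond the scatter is expected in this assay: a step that the limit leaves unreadable from compound 2 to compound 4. Compound 4 is therefore expected to land at 150000 nM, with a range from 60000 nM to 400000 nM, and most probably it will again be reported only as a limit.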

Compound 4, half-maximal inhibitory concentration: > 100000 nM
Compound 4 gave a limit, no number; the forecaster's own chance of this, stated with the estimate: 80%; the middle value lies beyond the limit too.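

In this assay no step can be read between compound 2 and compound 4, since both give limits and not numbers: the limit of > 100000 nM in this assay, at which 4 of the 4 values shown sit.

The compounds shown leave open whether any member of this series reaches a measurable half-maximal inhibitory concentration, and whether chloro and ethoxy would then differ.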